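Dropping the bromo from compound 3: what to expect

The compounds below may be only part of what the source reports. "The series", "measured", "known", "first", "only" and "open" are said of these compounds alone.

Measured compounds:
Compound 1 `O=C(Nc1cccc(F)c1)N[C@H]1CC[C@H](Oc2ccc(F)cc2)CC1` — 8300 nM in a functional assay on CRL2813 cells (Homo sapiens) for cytotoxicity, read by sulforhodamine B assay, with a stated time of 5 days; a lower number here means a stronger inhibitor, a higher number a weaker inhibitor
Compound 2 `Cc1cccc(NC(=O)N[C@H]2CC[C@H](Oc3ccc(F)cc3)CC2)c1` — 14400 nM in this assay
Compound 3 `O=C(Nc1cccc(Br)c1)N[C@H]1CC[C@H](Oc2ccc(F)cc2)CC1` — 6200 nM in this assay

Among the three numbers, compound 3 has the lowest. The step of a 1.3-fold lower number from compound 1 to compound 3 (0.13 log units; within the scatter) lies within the scatter, so compounds 1 and 3 cannot be told apart here, whereas a 2.3-fold lower number from compound 2 to compound 3 (0.37 log units; beyond the scatter) is a modest step beyond it.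

Compound 4 `O=C(Nc1ccccc1)N[C@H]1CC[C@H](Oc2ccc(F)cc2)CC1` differs from compound 3 by hydrogen in place of bromo on an aromatic carbon. Among the compounds with values here, no measured pair removes a substituent outright; the two steps that bear on the change both end at compound 3 and swap one group for another, a 1.3-fold lower number from compound 1 to compound 3 (0.13 log units; within the scatter) and a 2.3-fold lower number from compound 2 to compound 3 (0.37 log units; beyond the scatter). Both place bromo at the low end of the three, so its loss is expected to move the number upward by a modest amount, a 1.9-fold higher number from compound 3 to compound 4 (0.29 log units; within the scatter), though a result within the scatter would not be surprising. Compound 4 is estimated at 12000 nM, with a range from 5000 nM to 30000 nM.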

Compound 4, half-maximal inhibitory concentration: 20000 nM
Estimate against measurement, compound 4: 1.7-fold (0.22 log units) below; the range from low to high includes it.
By their numbers in this assay, from the lowest: compounds 3, 1, 2 and 4 (each within the scatter of the next, the first and the last beyond it).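

In this assay taking the bromo away gives a 3.2-fold higher number from compound 3 to compound 4 (0.51 log units; beyond the scatter) and so shows that a substituent on this aromatic carbon, meta to a large group, can matter, which swaps among bromo, fluoro and methyl alone could not show. Hydrogen in place of fluoro gives a 2.4-fold higher number from compound 1 to compound 4 (0.38 log units; beyond the scatter) and points the same way, but methyl goes against any general pattern: hydrogen in its place gives a 1.4-fold higher number from compound 2 to compound 4 (0.14 log units; within the scatter) and so cannot be told apart from methyl here. Nothing measured on these compounds explains why bromo and fluoro differ from hydrogen while methyl does not. On these data alone, whether chloro or trifluoromethyl at this place would track bromo or methyl remains open. So does what an amine or a carboxylic acid there would do.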